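Notes on a sulfonyl tetralin series at the serotonin 6 receptor

A few compounds are considered here, and "the series" means these few. Any claim that something is new, unique, unknown or untested is made for them only; others in the source may bear on it.

Measured compounds:
compound 1, `CC(=N)NCC1CCCc2cc(S(=O)(=O)c3ccccc3)ccc21`: 0.631 nM
compound 2, `NC[C@@H]1CCCc2cc(S(=O)(=O)c3cccc(O)c3)ccc21`: 0.251 nM

In an assay on isolated protein for displacement of a labelled ligand from 5-hydroxytryptamine receptor 6 (Homo sapiens) (on this read-out higher numbers stand for weaker inhibition and lower numbers for stronger inhibition), compound 2 gives 0.251 nM and stands at the lowest number of the two measured. Compound 1 gives 0.631 nM in this assay, a higher number that lies beyond the scatter. For the measured compounds named here, the two compounds differ in more than one place, so no single step between them is counted.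

The next compound, compound 3, `COc1cccc(S(=O)(=O)c2ccc3c(c2)CCC[C@H]3CN)c1`, differs from compound 2 in one place only: methyl in place of hydrogen on an oxygen on an aromatic ring. In the words of the group names, hydroxy becomes methoxy on the aromatic ring attached to the sulfonyl group.

Going by the values given here, no measured pair here isolates this change, so no step size can be read from the data. The step from compound 2 to compound 3 in this assay is expected to be small, with a modest rise in the number as the more likely direction, but possibly none beyond the scatter, as a 2.0-fold higher number from compound 2 to compound 3 (0.30 log units; within the scatter). Compound 3 is estimated at 0.5 nM in this assay, with a range from 0.15 nM to 2 nM.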

Compound 3, inhibition constant: 0.398 nM
Estimate against measurement, compound 3: 1.3-fold (0.10 log units) above, and the stated range covers the measured number.
By their numbers in this assay, from the lowest: compounds 2, 3 and 1 (each within the scatter of the next, the first and the last beyond it).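

In this assay, for the compounds shown here, compounds 2 and 3 form the first pair that isolates a single change, and the result is a 1.6-fold higher number from compound 2 to compound 3 (0.20 log units; within the scatter). Hydroxy and methoxy on the aromatic ring attached to the sulfonyl group are therefore not separated on this read-out, and at this place the hydrogen on the oxygen can be replaced by methyl without a step beyond the scatter. Nothing available explains this result.

From the compounds shown here alone, whether the oxygen itself matters at this place remains open, as does the effect of a longer chain such as ethoxy or of a replacement for the oxygen-linked group such as an amine or a fluorine atom. Compound 1 has no group at this place on the aromatic ring, but it differs from compound 2 in more than one place, so the value of compound 1, 0.631 nM, cannot settle that question.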